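Nitro for fluoro on the cinnamate aryl across two cores

This account rests on a few compounds, and the source may have more. Where it says the series, first, only, none or still open, it means among the compounds named here.

Compound 1 `O=C1C=C[C@@H](OCc2ccccc2)[C@@H]([C@@H](COC(=O)/C=C/c2ccc(F)cc2)OCc2ccccc2)O1` and compound 2 `O=C1C=C[C@@H](OCc2ccccc2)[C@@H]([C@@H](COC(=O)/C=C/c2ccc([N+](=O)[O-])cc2)OCc2ccccc2)O1` share one core; compound 3 `CC(=O)O[C@@H]1C=CC(=O)O[C@@H]1[C@@H](COC(=O)/C=C/c1ccc(F)cc1)OC(C)=O` and compound 4 `CC(=O)O[C@@H]1C=CC(=O)O[C@@H]1[C@@H](COC(=O)/C=C/c1ccc([N+](=O)[O-])cc1)OC(C)=O` share another, and the difference between the two cores is not broken down here. In a functional assay on Jurkat cells (Homo sapiens) for antiproliferative activity, read by MTT assay, with a stated time of 6 days (a higher number here means a weaker inhibitor, a lower number a stronger inhibitor), compound 1 gives 4160 nM, compound 2 gives 5710 nM and compound 3 gives 5320 nM. The change nitro in place of fluoro on an aromatic carbon made a step of a 1.4-fold higher number from compound 1 to compound 2 (0.14 log units; within the scatter). The same change, (nitro in place of fluoro on an aromatic carbon), now leads to compound 4, at the same place on the other core. Among the measured compounds shown here, since the one measured instance of this change stayed within the scatter, the expected step in this assay is a 1.4-fold higher number from compound 3 to compound 4 (0.14 log units; within the scatter), resting on a 1.4-fold higher number from compound 1 to compound 2 (0.14 log units; within the scatter). Compound 4 is accordingly estimated at 7300 nM, between 3600 nM and 15000 nM.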

Compound 4, half-maximal inhibitory concentration: 580 nM
Compound 4: middle estimate off by 13-fold (1.10 log units), on the high side; measured number outside the range, below it.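

In this assay, nitro in place of fluoro gives a 9.2-fold lower number from compound 3 to compound 4 (0.96 log units; beyond the scatter), so the change does not carry over at a constant size from the core of compound 1 to the core of compound 3. The two instances differ: the same change on two cores in this assay, a 1.4-fold higher number (0.14 log units; within the scatter) from compound 1 to compound 2 and a 9.2-fold lower number (0.96 log units; beyond the scatter) from compound 3 to compound 4, 13-fold (1.10 log units) apart, beyond the scatter of two such steps This shows that the size and direction of the step depend on the core for these two cores, but with one step on each core it does not show which part of the core is responsible, nor whether this holds in any other assay.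

As far as these compounds go, whether a nitrile or an amine at the same place on the core of compound 3 would follow compound 4 or compound 3 remains open. Also open, from the compounds shown here alone, is which single difference between the two cores sets the size of the step.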